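Trading Dipropylamino for a Second Amine on the Chain

A few compounds are considered here, and "the series" means these few. Any claim that something is new, unique, unknown or untested is made for them only; others in the source may bear on it.

Three compounds have been measured in a functional assay on the whole organism with Mus musculus as the target, in the maximal electroshock model, at a dose of 50 mg/kg by the oral route; a lower number here means less inhibition, a higher number more inhibition at the dose given (going by the name of the read-out):
compound 1 `COc1ccccc1/C=C/c1ccccc1OCCCCN(C)C` gives 0%;
compound 2 `COc1cccc(/C=C/c2ccccc2)c1OCCCCN(C)C` gives 57.1%;
compound 3 `CCCN(CCC)CCCCOc1ccccc1/C=C/c1ccccc1` gives 0%.

Compound 3 stands level with compound 1, the two together at the bottom of the three numbers, while compound 2 sits beyond the scatter above both. Compound 4 `CN(C)CCN(C)CCCCOc1ccccc1/C=C/c1ccccc1` has not yet been tested. It differs from compound 3 in one place: (2-(dimethylamino)ethyl)(methyl)amino in place of dipropylamino on a saturated chain carbon, four bonds along the chain from an oxygen on an aromatic ring. Going by the values given here, no measured pair shows this change, so the expected step from compound 3 to compound 4 is estimated as a number 5 percentage points higher from compound 3 to compound 4 (within the scatter), no larger than the scatter, because compound 3 gives 0% and the chain and core stay the same. Compound 4 is therefore expected to give about 5%, in a range from 0% to 30%.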

Compound 4, a percentage reported as inhibition, in the whole organism at one dose (the size of the read-out at that dose, not a potency): 0%
Beside the measured number, compound 4's estimate is 5 percentage points above it; measured number inside the range.
By their numbers in this assay, from the lowest: compounds 1, 3 and 4 (each within the scatter of the next); then compound 2.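

Putting (2-(dimethylamino)ethyl)(methyl)amino in place of dipropylamino on this saturated chain carbon gives no change at the digits printed from compound 3 to compound 4 (within the scatter) in this assay. A second amine nitrogen in this group is therefore not enough to bring out inhibition on this core at this dose. Nothing available here bears on why the result came out this way.

As far as these compounds go, whether the same change would matter on a compound that already shows inhibition stays open. So does whether a ring amine such as piperidine or morpholine at this position would give any inhibition.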